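Series notes: mouse half-life, step from compound 2 to compound 3

The source may report more compounds than this note shows. Statements on the series, on what has been measured and on what is new or still open speak of the compounds shown alone.

Measured so far:
- compound 1, `CC(=O)c1ncc([C@@H](O)[C@H](O)[C@H](O)CO)s1`, in an ADME assay on the whole organism (strain 129/SvEvBrd x C57BL/6) for metabolic stability, with Mus musculus as the target; a lower number here means that the compound disappears faster, a higher number that the compound lasts longer: 0.9 h
- compound 2, `CN(C)C(=O)c1nc([C@@H](O)[C@H](O)[C@H](O)CO)c[nH]1`, in this assay: 4 h

For the measured compounds named here, of the two numbers, compound 2 holds the higher one; the only neighbour, compound 1, sits well below it, a gap beyond the usual scatter. The two compounds differ in more than one place, so no single change can be tied to that gap.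

Compound 3, `Cn1cnc(-c2nc([C@@H](O)[C@H](O)[C@H](O)CO)c[nH]2)c1`, is not yet measured. It departs from compound 2 as follows: 1-methyl-1H-imidazol-4-yl in place of dimethylcarbamoyl on an aromatic carbon. Going by the values given here, no measured pair shows the effect of this kind of exchange, so the direction is open. With a single aromatic unit taking the place of a small acyclic group on the same ring carbon, the expected step is a 1.6-fold lower number from compound 2 to compound 3 (0.20 log units; within the scatter), which stays within the usual scatter. Compound 3 is therefore expected at 2.5 h, with a range from 0.8 h to 8 h.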

Compound 3, half-life: 1.6 h
Compound 3: middle estimate off by 1.6-fold (0.19 log units), on the high side, within the range that was stated.
By their numbers in this assay, from the lowest: compounds 1 and 3 (each within the scatter of the next); then compound 2.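

For the compounds shown here, this is the first comparison that differs in one place only: on the aromatic carbon between two ring nitrogen atoms, 1-methyl-1H-imidazol-4-yl in place of dimethylcarbamoyl gives a 2.5-fold lower number from compound 2 to compound 3 (0.40 log units; beyond the scatter) in this assay. The half-life thus responds to this exchange at this position, and a group with no ring gives the longer half-life of this single pair, though the step is modest. Nothing at hand accounts for the shift.

One pair cannot separate the loss of the carbonyl from the entry of the aromatic ring, and a phenyl group on the same ring carbon would help to tell these apart. On these data alone, whether a primary carboxamide or a cyclic amide such as the morpholine amide would keep the half-life of compound 2 also remains open.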